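The compounds below may be only part of what the source reports. "The series", "measured", "known", "first", "only" and "open" are said of these compounds alone.

Compound 1, `C#Cc1cccc(-n2ccc3cc(OC)cc(OC)c3c2=O)c1`, was tested in a functional assay on A549 cells (Homo sapiens) for antiproliferative activity, read by MTT assay, with a stated time of 72 h (a higher number here means a weaker inhibitor, a lower number a stronger inhibitor), and in it compound 1 gives 25200 nM. Compound 2, `C#Cc1cccc(-n2ccc3cc(OC)cc(O)c3c2=O)c1`, differs from compound 1 by hydrogen in place of methyl on an oxygen on an aromatic ring, and in this assay compound 2 gives 15900 nM. That single change produced a 1.6-fold lower number from compound 1 to compound 2 (0.20 log units; within the scatter), so the two numbers are not distinguishable by this measurement.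

Compound 3, `COc1cc2c(c(OC)c1)C(=O)N(c1cccc(C(=O)N3CCCCC3)c1)CC2`, is built on another core; the difference between the two cores is not broken down here. In this assay compound 3 gives 23400 nM. This number sits close to that of compound 1 and of compound 2, and all three values lie within the usual scatter of one another, so none of the three can be called more or less potent than the others on this evidence.

Compound 4, `COc1cc(O)c2c(c1)CCN(c1cccc(C(=O)N3CCCCC3)c1)C2=O`, has not yet been measured. It differs from compound 3 by hydrogen in place of methyl on an oxygen on an aromatic ring, the same change that separates compound 1 from compound 2, made at the same kind of position. The expected step from compound 3 to compound 4 is a 1.6-fold lower number from compound 3 to compound 4 (0.19 log units; within the scatter), an expectation that rests on the earlier pair, because the same change gave a 1.6-fold lower number from compound 1 to compound 2 (0.20 log units; within the scatter). In this assay compound 4 is therefore expected to give about 15000 nM, most likely between 6000 nM and 40000 nM.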

Compound 4, half-maximal inhibitory concentration: 13200 nM
The estimate for compound 4 lay 1.1-fold (0.06 log units) above the measured number; measured number inside the range.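

In this assay, hydrogen in place of methyl on an oxygen on an aromatic ring, methoxy to hydroxy, gave a 1.8-fold lower number from compound 3 to compound 4 (0.25 log units; within the scatter), so this measurement cannot tell the two numbers apart. Set beside the earlier pair, the change reads alike on the two cores: the same change on two cores in this assay, a 1.6-fold lower number (0.20 log units; within the scatter) from compound 1 to compound 2 and a 1.8-fold lower number (0.25 log units; within the scatter) from compound 3 to compound 4, 1.1-fold (0.05 log units) apart, within the scatter of two such steps. This shows that the step carries from the core of compound 1 to the core of compound 3 without a detectable difference, but each step lies within the scatter, so it does not show that the change alters the antiproliferative read-out on either core, and two pairs in one assay set no rule for other cores in the series.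

The compounds shown leave open whether a longer chain on that oxygen, such as ethoxy, or an amine in place of the methoxy or hydroxy group, would give a number that stands clear of the scatter. They also leave open whether the step would stay the same on compounds carrying a carboxylic acid elsewhere in the structure.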